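Series notes: cyclopentyl in place of the acyl group

The source may hold more compounds than are shown below. What is called first, only, known or untested is meant among the compounds shown, and "the series" means these compounds.

Measured compounds:
- compound 1, `Nc1ncc(-c2ccc(Cl)cc2)c(-c2ccccc2)n1`: 41%
- compound 2, `CCCC(=O)Nc1ncc(-c2cccc(Cl)c2)c(-c2ccccc2)n1`: > 80%

In an assay on CHO cells for displacement of a labelled ligand from adenosine receptor A1 (Homo sapiens), read by scintillation counting, with a stated time of 1 h, tested at 1 uM (a higher number here means more inhibition at the concentration tested (going by the name of the read-out), a lower number less inhibition), compound 1 gives 41%. For compound 2 the read-out of > 80% in this assay is a limit of the assay and not a number. Going by these compounds, compound 2 thus sits at the limit of > 80% in this assay, at which 1 of the 2 values shown sits, and how far beyond that mark it lies is unknown. Compound 1 and compound 2 differ in more than one place, so their two values show only that one reaches the limit and the other does not.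

Compound 3, `Clc1cccc(-c2cnc(NC3CCCC3)nc2-c2ccccc2)c1`, is compound 2 with cyclopentyl in place of propylcarbonyl on a nitrogen on an aromatic ring. Among the compounds with values here, no pair of measured compounds differing in a single place exists here, so no measured step size can be carried over. The carbonyl leaves with the change and a saturated ring takes its place on the ring nitrogen; compound 2 itself is known only as a limit, which leaves the starting point uncertain. A drop of moderate size, beyond the usual scatter, is expected, a number at least 15 percentage points lower from compound 2 to compound 3 (beyond the scatter). Compound 3 is expected to give 65% in this assay, within 35% to 90%.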

Compound 3, a percentage reported as inhibition, at one concentration (the size of the read-out at that concentration, not a potency): > 80%
Compound 3 gave a limit, no number (the forecaster's own chance of this, stated with the estimate: 35%); middle value at least 15 percentage points away from the limit.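

In this assay compound 3 gives > 80%, a limit and not a number. Compound 2 is also known only as a limit, so no step can be read between compound 2 and compound 3: the limit of > 80% in this assay, at which 2 of the 3 values shown sit.

The compounds shown leave open how far past this limit each of the two lies, and whether cyclopentyl in place of propylcarbonyl changes the read-out at all.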